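The compounds below may be only part of what the source reports. "The series", "measured", "known", "first", "only" and "open" are said of these compounds alone.

Measured in a functional assay on SK-MEL-28 cells (Homo sapiens) for inhibition, read by sulforhodamine B assay, with a stated time of 48 h; a lower number here means that less compound is tolerated, a higher number that more compound is tolerated:
Compound 1, `COc1cc(-c2nn(-c3cccc(NC(=O)Nc4ccc(Cl)c(Cl)c4)c3)cc2-c2ccncc2)ccc1Cl`, stops at the limit > 50000 nM.
Compound 2, `O=C(Nc1cccc(-n2cc(-c3ccncc3)c(-c3ccc(Cl)c(O)c3)n2)c1)Nc1cc(C(F)(F)F)cc(C(F)(F)F)c1`, gives 3090 nM.
Compound 3, `COc1cc(-c2nn(-c3cccc(NC(=O)Nc4ccc(Cl)c(C(F)(F)F)c4)c3)cc2-c2ccncc2)ccc1Cl`, gives 19100 nM.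

Compound 1 is therefore known here only as a limit, (the limit of > 50000 nM in this assay, at which 1 of the 3 values shown sits), not as a number. Compound 4, `COc1cc(-c2nn(-c3cccc(NC(=O)c4ccccc4)c3)cc2-c2ccncc2)ccc1Cl`, differs from compound 1 in one place: phenyl in place of (3,4-dichlorophenyl)amino on a carbonyl carbon. The single measured step among these compounds, an at least 2.6-fold lower number from compound 1 to compound 3 (0.41 log units; beyond the scatter), concerns another part of the molecule, a chloro giving way to trifluoromethyl, and no measured step touches the urea itself. With nothing to guide the direction, compound 4 is expected to remain near the limit in this assay, and the estimate is 50000 nM (range 15000 nM to 100000 nM), meaning an expected step of a number no higher from compound 1 to compound 4 (the limit leaves the size open).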

Compound 4, concentration lethal to 50% of the cells: > 100000 nM
Compound 4 was reported as a limit; the forecaster's own chance of this, stated with the estimate: 55%; middle value at least 2.0-fold (0.30 log units) from the limit.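

In this assay compound 4 is known only as a limit: the limit of > 100000 nM in this assay, at which 1 of the 4 values shown sits. Among the compounds shown here, on this carbonyl carbon, phenyl in place of (4-chloro-3-(trifluoromethyl)phenyl)amino gives an at least 5.2-fold higher number from compound 3 to compound 4 (0.71 log units; beyond the scatter), the first readable step at this place in the molecule. The step from compound 1 cannot be read, since both of its values are limits.

The compounds shown leave open whether this step follows the loss of the amino hydrogen or of the chloro and trifluoromethyl groups on the ring. A 4-chloro-3-(trifluoromethyl)phenyl or a cyclohexylamino group on the same carbonyl carbon could begin to separate these.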